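A few compounds are considered here, and "the series" means these few. Any claim that something is new, unique, unknown or untested is made for them only; others in the source may bear on it.

Measured in an ADME assay on RAW264.7 cells (Mus musculus) for cytotoxicity, read by MTT assay, with a stated time of 24 h, in the presence of a further agent that is not named here; on this read-out higher numbers stand for weaker inhibition and lower numbers for stronger inhibition:
- Compound 1 `COc1ccc(C(O)C2OC(=O)c3c(OC)cc(OC)cc32)cc1`: > 40000 nM, a limit
- Compound 2 `COc1cc(OC)c2c(c1)C(C(O)c1ccc(OCc3ccc(C#N)cc3)cc1)OC2=O`: > 40000 nM, a limit

Within the data shown here, compound 2 has no exact number, only this limit, and the one other value known is a limit as well. The whole record so far is the limit of > 40000 nM in this assay, at which 2 of the 2 values shown sit.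

Compound 3 `COc1cc(OC)c2c(c1)C(C(O)c1ccc(OCc3ccc(OC(F)(F)F)cc3)cc1)OC2=O` differs from compound 2 in a single place: trifluoromethoxy in place of cyano on an aromatic carbon. In short, trifluoromethoxy stands in place of cyano on an aromatic carbon.

Among the measured compounds shown here, the one measured step that bears on this, a step that the two limits leave unreadable from compound 1 to compound 2, put 4-cyanophenyl in place of hydrogen and shows no size, so it gives no ground for expecting a change in this assay. The estimated a number no higher from compound 2 to compound 3 (the limit leaves the size open) therefore stays within the scatter, with no direction expected. For compound 3 the expected value is 40000 nM, with an estimated range of 20000 nM to 80000 nM.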

Compound 3, half-maximal inhibitory concentration: > 40000 nM
Compound 3 gave a limit, no number; the forecaster's own chance of this, stated with the estimate: 85%; the middle value sits exactly at the limit.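

Compound 3 gives only a limit, as do compound 1 and compound 2, so no step among these three compounds can be read in this assay: the limit of > 40000 nM in this assay, at which 3 of the 3 values shown sit.

The compounds shown leave open whether trifluoromethoxy in place of cyano changes this read-out at all, and by how much.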